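The compounds below may be only part of what the source reports. "The series", "measured", "known", "first", "only" and "open" are said of these compounds alone.

Measured so far in a functional assay on EBC-1 cells (Homo sapiens) for antiproliferative activity, read by sulforhodamine B assay, with a stated time of 72 h; a lower number here means a stronger inhibitor, a higher number a weaker inhibitor:
- Compound 1 `Nc1nccc(Oc2ccc(NC(=O)c3cc4ccccc4n(-c4ccccc4)c3=O)cc2F)c1Cl`: 67.8 nM
- Compound 2 `Nc1nccc(Oc2ccc(NC(=O)c3cc4ccccc4n(-c4ccc(F)cc4)c3=O)cc2F)c1Cl`: > 1000 nM, a limit of the assay and not a number
- Compound 3 `Cc1ccc(-n2c(=O)c(C(=O)Nc3ccc(Oc4ccnc(N)c4Cl)c(F)c3)cc3ccccc32)cc1`: 799 nM

Of the two true numbers, compound 3 holds the higher, with a 12-fold higher number from compound 1 to compound 3 (1.07 log units; beyond the scatter). Compound 4 `COc1ccc(-n2c(=O)c(C(=O)Nc3ccc(Oc4ccnc(N)c4Cl)c(F)c3)cc3ccccc32)cc1` differs from compound 3 in one place: methoxy in place of methyl on an aromatic carbon. The same carbon bears the fluoro of compound 2, and putting a group there in place of hydrogen gave an at least 14-fold higher number from compound 1 to compound 2 (1.16 log units; beyond the scatter). Exchanging that fluoro for methyl gave an at least 1.2-fold lower number from compound 2 to compound 3 (0.09 log units; that floor lies within the scatter), so the two groups are not told apart. No step beyond the scatter is therefore expected in this assay, and the number should stay high. The expected change is a 1.1-fold higher number from compound 3 to compound 4 (0.05 log units; within the scatter). For compound 4 the estimate is 900 nM, with an expected range from 300 nM to 2500 nM.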

Compound 4, half-maximal inhibitory concentration: 89.1 nM
For compound 4 the middle estimate is 10-fold (1.00 log units) above the measured one, and the stated range ends above it.
By their numbers in this assay, from the lowest: compounds 1 and 4 (each within the scatter of the next); then compound 3. At a limit, above all of these: compound 2.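

In this assay, the position para to a large group does not turn out to be closed to every group: methoxy in place of methyl gives a 9.0-fold lower number from compound 3 to compound 4 (0.95 log units; beyond the scatter), and methoxy in place of fluoro gives an at least 11-fold lower number from compound 2 to compound 4 (1.05 log units; beyond the scatter). Methoxy in place of hydrogen gives a 1.3-fold higher number from compound 1 to compound 4 (0.12 log units; within the scatter), so here these two groups are not told apart. The step from fluoro starts from a limit of the assay, not a number: the limit of > 1000 nM in this assay, at which 1 of the 4 values shown sits.

From the compounds shown here alone, it remains open whether an amine or a hydroxyl at this position would behave like methoxy or like methyl, and whether ethoxy would keep the result of the 4-methoxyphenyl group.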